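Sulfanyl in place of methylselanyl on the shared core

The source may report more compounds than this note shows. Statements on the series, on what has been measured and on what is new or still open speak of the compounds shown alone.

Compound 1 `COc1ccc(CNc2nc([Se]C)nc3ccccc23)cc1` is assessed in a functional assay on HTB-54 cells (Homo sapiens) for cytotoxicity, read by MTT assay, with a stated time of 72 h; on this read-out higher numbers stand for weaker inhibition of growth and lower numbers for stronger inhibition of growth. In this assay compound 1 stops at > 100000 nM, which is a limit of the assay and not a number. Compound 1 therefore sits at the limit of > 100000 nM in this assay, at which 2 of the 3 values shown sit. Compound 2 `C[Se]c1nc(NCc2ccccc2)c2ccccc2n1` likewise stops at the limit > 100000 nM. Compound 3 `CSc1ccc(CNc2nc([Se]C)nc3ccccc23)cc1` gives 72400 nM. The measured steps are an at least 1.3-fold lower number from compound 1 to compound 3 (0.14 log units; that floor lies within the scatter) and an at least 1.3-fold lower number from compound 2 to compound 3 (0.14 log units; that floor lies within the scatter), while a step that the two limits leave unreadable from compound 1 to compound 2. Compound 4 `COc1ccc(CNc2nc(S)nc3ccccc23)cc1` differs from compound 1 by one sulfur atom in place of a group of 2 heavy atoms (1 carbon, 1 selenium; no ring), on an aromatic carbon. For the measured compounds named here, none of the measured steps touches this position; they all concern the aromatic carbon bearing methoxy, hydrogen or methylsulfanyl. Going by the values given here, with no step to read from, compound 4 is expected near 100000 nM, ranging from 30000 nM to 300000 nM. The step of a number no higher from compound 1 to compound 4 (the limit leaves the size open) is accordingly estimated as nothing beyond the scatter.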

Compound 4, concentration for total growth inhibition: 45500 nM
Estimate against measurement, compound 4: 2.2-fold (0.34 log units) above, and the stated range covers the measured number.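

Sulfanyl in place of methylselanyl gives the only step shown that clears the scatter in this assay, with an at least 2.1-fold lower number from compound 1 to compound 4 (0.34 log units; beyond the scatter). The earlier steps shown here all concerned the aromatic carbon bearing methoxy, hydrogen or methylsulfanyl, and none of their floors cleared the scatter. This step too is only a floor, since compound 1 stands at a limit of the assay and not at a number: the limit of > 100000 nM in this assay, at which 2 of the 4 values shown sit.

The compounds shown leave open how an amine or a longer chain would read on this carbon. They also leave open whether the step holds with hydrogen or methylsulfanyl in place of methoxy.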